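Swapping Methoxy for Trifluoromethyl on an Aryl Ester

This account rests on a few compounds, and the source may have more. Where it says the series, first, only, none or still open, it means among the compounds named here.

Measured compounds:
- compound 1, `COc1ccc(C(=O)Oc2cc3c(cc2C)[C@@H](C(C)C)CC=C3C)cc1`: 46.5%
- compound 2, `Cc1cc2c(C(C)C)ccc(C)c2cc1OC(=O)c1ccc(C(F)(F)F)cc1`: 45.1%
- compound 3, `CC1=CC[C@H](C(C)C)c2cc(C)c(OC(=O)c3cccc(Cl)c3)cc21`: "not active" (no number reported)

In a functional assay on K562 cells (Homo sapiens) for antiproliferative activity, read by sulforhodamine B assay, with a stated time of 48 h, tested at 50 uM (on this read-out higher numbers stand for more inhibition at the one concentration tested (going by the name of the read-out) and lower numbers for less inhibition), compound 1 gives 46.5%, and compound 2 gives 45.1%. These two numbers lie within the usual scatter of each other, so neither compound can be set above the other. Compound 3, which carries a chlorine on the ester aryl ring, was reported as not active in this assay, and no number was given for it.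

Compound 4, `CC1=CC[C@H](C(C)C)c2cc(C)c(OC(=O)c3ccc(C(F)(F)F)cc3)cc21`, has not yet been measured in this assay. It differs from compound 1 in one place: trifluoromethyl in place of methoxy on an aromatic carbon. Compound 2 already carries the same trifluoromethyl group on a related core and its value sits close to that of compound 1, so no step beyond the scatter is expected from compound 1 to compound 4 in this assay. For compound 4 the expected value is 45%, with a range from 25% to 60%, which means an expected step of a number 1.5 percentage points lower from compound 1 to compound 4 (within the scatter).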

Compound 4, a percentage reported as inhibition, at one concentration (the size of the read-out at that concentration, not a potency): 9%
Beside the measured number, compound 4's estimate is 36 percentage points above it, outside the stated range (below it).
By their numbers in this assay, from the lowest: compound 4; then compounds 2 and 1 (each within the scatter of the next).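

In this assay, the aromatic carbon para to a large group proves sensitive to what it carries: trifluoromethyl in place of methoxy gives a number 37.5 percentage points lower from compound 1 to compound 4 (beyond the scatter). For the compounds shown here, no earlier pair differed in this one place, so this is the only direct reading of the swap on this core, and it shows that the two groups are not interchangeable here. Nothing in the data shown explains the drop.

Going by these compounds, whether an amine, a carboxylic acid or a longer chain such as ethoxy on this carbon would stay close to compound 1 or fall towards compound 4 remains open. Going by these compounds alone, also open is how far the size of this step depends on the core, since only one pair on one core can be read here.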